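This account rests on a few compounds, and the source may have more. Where it says the series, first, only, none or still open, it means among the compounds named here.

Measured in a functional assay on MM1 cells (Homo sapiens) for antiproliferative activity, read by MTT assay, with a stated time of 72 h; on this read-out lower numbers stand for stronger inhibition and higher numbers for weaker inhibition:
- compound 1 `N#C/C(=C\c1cccc(Br)n1)C(=O)N[C@@H](CO)c1ccccc1` gives 2800 nM
- compound 2 `COc1cccc([C@H](C)NC(=O)/C(C#N)=C/c2cccc(Br)n2)c1` gives 2400 nM
- compound 3 `CCC[C@H](NC(=O)/C(C#N)=C/c1ccc(Cl)c([N+](=O)[O-])c1)c1ccccc1` gives 1580 nM

Compound 1 stands within the scatter of both compound 2 and compound 3, so the three values give no order. Compound 4 (`CC(=O)OC[C@H](NC(=O)/C(C#N)=C/c1cccc(Br)n1)c1ccccc1`) has acetyl in place of hydrogen on an oxygen on a saturated carbon, hydroxy to acetoxy (acetyl in place of hydrogen on an oxygen on a saturated carbon). Going by the values given here, no measured pair shows this change, so the series does not size it directly. Among the compounds with values here, the only guide is the narrow spread of values, from compound 1 at 2800 nM to compound 3 at 1580 nM. In this assay no step beyond the scatter is expected, with a slight lean towards a lower number. The estimated change is a 1.4-fold lower number from compound 1 to compound 4 (0.15 log units; within the scatter) and is expected to stay small. Compound 4 is expected at 2000 nM (estimated range 800 nM to 5000 nM).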

Compound 4, half-maximal inhibitory concentration: 2600 nM
Compound 4: the middle estimate sits 1.3-fold (0.11 log units) below what was measured; measured number inside the range.
By their numbers in this assay, from the lowest: compounds 3, 2, 4 and 1 (each within the scatter of the next).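

In this assay, going by these compounds alone, the change from hydroxy to acetoxy gives a 1.1-fold lower number from compound 1 to compound 4 (0.03 log units; within the scatter) and provides the only direct reading of this position. Acetyl in place of hydrogen on this oxygen therefore leaves the number within the scatter, so a free hydroxy is not needed to hold activity at this level in this pair. Nothing at hand gives a reason for this result. On these data alone, it remains open whether an amine or a carboxylic acid in place of the hydroxy would leave the number equally unmoved.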